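This account rests on a few compounds, and the source may have more. Where it says the series, first, only, none or still open, it means among the compounds named here.

Compound 1 (`O=C(/C=C/c1cccc(C(F)(F)F)c1)NCCO`) - 117 mg/kg
Compound 2 (`CN1C(=O)CCC1(O)c1cccc(C(F)(F)F)c1`) - 129 mg/kg

Both compounds were tested in a functional assay on the whole organism with Mus musculus as the target (a lower number here means that less compound is needed, a higher number that more compound is needed for the effect), and both gave a number. Compound 2 stands level with compound 1, as the two values lie within the usual scatter of each other. They share a trifluoromethyl group but little else, so the pair says nothing about how a single change acts.

Compound 3 (`CCCN1C(=O)CCC1(O)c1cccc(C(F)(F)F)c1`) has not yet been measured. It differs from compound 2 by ethyl in place of hydrogen on a saturated chain carbon bound to an amide-type nitrogen in a ring and so turns methyl into propyl. For the measured compounds named here, no measured pair shows a change of this kind, and the data point in no direction. No step beyond the scatter is therefore expected, and the estimated change is a 1.2-fold lower number from compound 2 to compound 3 (0.07 log units; within the scatter) in this read-out. In this assay the estimated value for compound 3 is 110 mg/kg with an expected range from 55 mg/kg to 220 mg/kg.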

Compound 3, dose for half-maximal effect: > 200 mg/kg
Compound 3 gave a limit, no number (the forecaster's own chance of this, stated with the estimate: 15%); at least 1.8-fold (0.25 log units) between middle value and limit.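

Compound 3 gave only a limit in this assay, > 200 mg/kg, and not a number. For the compounds shown here, this is the first single change that can be read in the set: going from methyl to propyl gives an at least 1.5-fold higher number from compound 2 to compound 3 (0.19 log units; that floor lies within the scatter), so the longer chain shows no sign of lowering the dose needed, although the floor of this step does not by itself establish a loss beyond the scatter. The reading therefore rests on one censored result: the limit of > 200 mg/kg in this assay, at which 1 of the 3 values shown sits.

On these data alone, how far the true value of compound 3 lies from that of compound 2 remains open, and so does whether the step exceeds the scatter. Also open, as far as these compounds go, is how a butyl chain, a benzyl group or a terminal carboxylic acid would act at this position.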